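From fluoro to chloro on compound 3

The source may report more compounds than this note shows. Statements on the series, on what has been measured and on what is new or still open speak of the compounds shown alone.

Measured so far:
Compound 1 `CN1C/C(=C\c2ccc(C#N)cc2)C(=O)/C(=C/c2ccccc2F)C1` gives 2670 nM
Compound 2 `CN1C/C(=C\c2cccc(Br)c2)C(=O)/C(=C/c2cccc([N+](=O)[O-])c2)C1` gives 12200 nM
Compound 3 `CN1C/C(=C\c2ccc(F)cc2)C(=O)/C(=C/c2ccc(C#N)cc2)C1` gives 11300 nM

These three values come from a functional assay on K562 cells (Homo sapiens) for cytotoxicity, read by MTT assay, with a stated time of 24 h (on this read-out lower numbers stand for stronger inhibition and higher numbers for weaker inhibition), and are all that is known so far. Compound 3 at 11300 nM lies within the scatter of compound 2 at 12200 nM while compound 1 at 2670 nM stands clearly lower.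

The unmeasured compound 4 `CN1C/C(=C\c2ccc(Cl)cc2)C(=O)/C(=C/c2ccc(C#N)cc2)C1` differs from compound 3 in one place: chloro in place of fluoro on an aromatic carbon with chloro in place of fluoro on an aromatic carbon. Among the measured compounds shown here, only one measured step bears on this change, and only loosely. It is a 4.2-fold higher number from compound 1 to compound 3 (0.63 log units; beyond the scatter) and it is modest. For the measured compounds named here, that step swaps 2-fluorophenyl for 4-fluorophenyl, so it keeps the fluoro and shows only that a change at this phenyl can move the number. Going by the values given here, no measured pair exchanges one halogen for another, so no direction can be drawn from the data, and no step beyond the scatter is expected in this assay here. The step expected is a 1.2-fold lower number from compound 3 to compound 4 (0.08 log units; within the scatter) with a wide margin on either side. For compound 4 the estimated value is 9500 nM with an expected range from 3500 nM to 24000 nM in this assay.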

Compound 4, half-maximal inhibitory concentration: 13300 nM
Estimate against measurement, compound 4: 1.4-fold (0.15 log units) below; measured number inside the range.
By their numbers in this assay, from the lowest: compound 1; then compounds 3, 2 and 4 (each within the scatter of the next).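

In this assay, the exchange of one halogen for another on this phenyl gives a 1.2-fold higher number from compound 3 to compound 4 (0.07 log units; within the scatter), so 4-chlorophenyl and 4-fluorophenyl cannot be told apart here while the rest of compound 3 stays as it is. The wider change of 4-chlorophenyl in place of 2-fluorophenyl gives a 5.0-fold higher number from compound 1 to compound 4 (0.70 log units; beyond the scatter), and alongside a 4.2-fold higher number from compound 1 to compound 3 (0.63 log units; beyond the scatter) this shows that the gap to compound 1 remains with either halogen on that phenyl, so it does not depend on which of the two is present. No data given here account for this result.

From the compounds shown here alone, whether an amine or a methoxy group in place of the halogen on this aromatic carbon would move the number beyond the scatter remains open, as does whether any group there would do so. Equally open, going by these compounds, is whether chloro in place of fluoro would remain as small a step on the 2-fluorophenyl of compound 1 , which stands at 2670 nM in this assay.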